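Moving a chlorine around the phenyl ring of a tetrabromobenzotriazole

The compounds below may be only part of what the source reports. "The series", "measured", "known", "first", "only" and "open" are said of these compounds alone.

Compound 1, `OC(CCn1nc2c(Br)c(Br)c(Br)c(Br)c2n1)c1cccc(Cl)c1`, was tested in a functional assay on MCF7 cells (Homo sapiens) for antiproliferative activity, read by MTT assay, with a stated time of 24 h, tested at 100 uM (on this read-out higher numbers stand for a weaker effect at the one concentration tested and lower numbers for a stronger effect), and compound 1 gives 0%. Its closest measured relative is compound 2, `OC(CCn1nc2c(Br)c(Br)c(Br)c(Br)c2n1)c1ccc(Br)cc1`, which in this assay gives 0%. Within the data shown here, the one step between them, no change at the digits printed from compound 1 to compound 2 (within the scatter), tells that exchanging the halogenated phenyl on the chain carbon bearing the hydroxyl group left the read-out where it was. Compound 1 therefore stands level with compound 2 at the digits shown, with nothing in this pair separating the two.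

The next compound, compound 3, `OC(CCn1nc2c(Br)c(Br)c(Br)c(Br)c2n1)c1ccc(Cl)cc1`, differs from compound 1 only in the position of the chlorine on the phenyl ring: 4-chlorophenyl in place of 3-chlorophenyl on a saturated chain carbon bound to an oxygen on a saturated carbon and a saturated chain carbon.

Among the measured compounds shown here, only the step from compound 1 to compound 2 bears on this change, and it was flat within the scatter, even though it swapped both the halogen and its position. A change that keeps the halogen and moves it alone is expected to do no more. The step from compound 1 to compound 3 is expected to be no change at the digits printed from compound 1 to compound 3 (within the scatter), so in this assay compound 3 is estimated at 0%, within the range 0% to 15%.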

Compound 3, a percentage reported as activity, at one concentration (the size of the read-out at that concentration, not a potency): 0%
Compound 3: the middle estimate sits on the measured number at the digits printed, within the range that was stated.
By their numbers in this assay, from the lowest: compounds 1, 2 and 3 (each within the scatter of the next).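

In this assay, moving the chlorine alone gives no change at the digits printed from compound 1 to compound 3 (within the scatter), so the position of this halogen on the ring, tested without any other change, leaves the read-out where it was. Exchanging the halogen alone, with chloro in place of bromo on an aromatic carbon, gives no change at the digits printed from compound 2 to compound 3 (within the scatter), so the two changes combined in the earlier step have now each been seen by themselves, and neither moves the number. No supporting measurement is available that would explain why these halogen changes make no difference.

All three compounds carry a halogen on the phenyl ring and keep the same hydroxyl-bearing chain, so these results say nothing about how a quite different group would behave at this place, such as a carboxylic acid or an amine on the ring in place of the chlorine. Also open, on these data alone, is whether a longer chain or a ketone in place of the hydroxyl-bearing carbon would shift the read-out in this assay at all.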